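Series notes: adding a methoxy to the core of compound 1

The source may hold more compounds than are shown below. What is called first, only, known or untested is meant among the compounds shown, and "the series" means these compounds.

Among the measured compounds shown here, compound 1 `COc1ccc(C(=O)c2cc(OC)c(OC)c(OC)c2)cc1NC(=O)/C=C/c1ccc(OC)c(OC)c1` holds the lowest of the two numbers measured so far. For the measured compounds named here, in a functional assay on HT-29 cells (Homo sapiens) for cytotoxicity, read by MTT assay, with a stated time of 72 h (on this read-out higher numbers stand for weaker inhibition and lower numbers for stronger inhibition), compound 1 gives 2500 nM, while compound 2 `COc1ccc(C(=O)c2cc(OC)c(OC)c(OC)c2)cc1NC(=O)/C=C/c1ccc([N+](=O)[O-])cc1` gives 5100 nM; the single measured step is a 2.0-fold higher number from compound 1 to compound 2 (0.31 log units; beyond the scatter). That step alters the aryl group on the double-bonded chain carbon and leaves the core untouched. Compound 3 `COc1ccc(/C=C/C(=O)Nc2cc(C(=O)c3cc(OC)c(OC)c(OC)c3)cc(OC)c2OC)cc1OC` differs from compound 1 in another place altogether: methoxy in place of hydrogen on an aromatic carbon. Going by the values given here, no measured step touches the core in this way, so the step from compound 1 to compound 2 offers no direct guide, and nothing shows whether an added methoxy here moves the number. The expected step is therefore a 1.2-fold higher number from compound 1 to compound 3 (0.08 log units; within the scatter), which is taken as no change beyond the scatter, with a wide range to reflect the missing evidence. For compound 3 the estimate in this assay is 3000 nM, expected to lie between 900 nM and 10000 nM.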

Compound 3, half-maximal inhibitory concentration: 2300 nM
For compound 3 the middle estimate is 1.3-fold (0.12 log units) above the measured one; low and high end bracket the measured number.
By their numbers in this assay, from the lowest: compounds 3 and 1 (each within the scatter of the next); then compound 2.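

With the added methoxy on the aromatic carbon ortho to a methoxy group and meta to two large groups, this assay gives a 1.1-fold lower number from compound 1 to compound 3 (0.04 log units; within the scatter), so compound 3 and compound 1 cannot be told apart at this position. Among the compounds shown here, this is the first measured change on the shared core, whereas the earlier step, a 2.0-fold higher number from compound 1 to compound 2 (0.31 log units; beyond the scatter), concerned only the aryl group on the chain and lay beyond the scatter. At this carbon, then, methoxy in place of hydrogen produces no step beyond the scatter, and no evidence on the reason for this is at hand.

Still open, from the compounds shown here alone, is whether an ethoxy, an amine or a carboxylic acid at this carbon would give a step beyond the scatter. Also open, going by these compounds, is whether the added methoxy gives the same result when 4-nitrophenyl, as in compound 2, replaces 3,4-dimethoxyphenyl on the chain.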